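This account rests on a few compounds, and the source may have more. Where it says the series, first, only, none or still open, it means among the compounds named here.

In an ADME assay on CCRF-CEM cells (Homo sapiens) for antiproliferative activity, with a stated time of 48 h (a higher number here means a weaker inhibitor, a lower number a stronger inhibitor), compound 1 `C=C(Br)C(=O)Nc1ccc(C(=O)/C=C/c2ccc(OC)cc2)cc1` gives 1100 nM, compound 2 `C=C(Br)C(=O)Nc1ccc(C(=O)/C=C/c2cccc(OC)c2)cc1` gives 1800 nM and compound 3 `C=C(Br)C(=O)Nc1ccc(C(=O)/C=C/c2ccc(OC)c(OC)c2)cc1` gives 1600 nM, so compound 1 stands level with both others within the scatter. Compound 4 `C=C(Br)C(=O)Nc1ccc(C(=O)/C=C/c2ccc(OC)cc2OC)cc1` differs from compound 1 in one place, methoxy in place of hydrogen on an aromatic carbon. The same kind of change appears in a 1.5-fold higher number from compound 1 to compound 3 (0.16 log units; within the scatter) and in a 1.1-fold lower number from compound 2 to compound 3 (0.05 log units; within the scatter), while moving the methoxy group gave a 1.6-fold higher number from compound 1 to compound 2 (0.21 log units; within the scatter). All three steps lie within the scatter, though none puts a methoxy group on this carbon. The expected step is therefore a 1.4-fold higher number from compound 1 to compound 4 (0.13 log units; within the scatter), with no change beyond the scatter anticipated. For compound 4, the estimated value is 1500 nM, within an expected range of 800 nM to 2800 nM.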

Compound 4, half-maximal inhibitory concentration: 1100 nM
Compound 4: the middle estimate sits 1.4-fold (0.13 log units) above what was measured, within the range that was stated.
By their numbers in this assay, from the lowest: compounds 1, 4, 3 and 2 (each within the scatter of the next).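

In this assay, a methoxy group on this aromatic carbon, ortho to a large group and meta to a methoxy group, gives no change at the digits printed from compound 1 to compound 4 (within the scatter). Among these compounds, no earlier compound carried a group on this carbon, and here the added methoxy leaves the number level with that of the parent. The same change also reads alike on the two cores where it can be compared: the same change on two cores in this assay, a 1.1-fold lower number (0.05 log units; within the scatter) from compound 2 to compound 3 and no change at the digits printed (within the scatter) from compound 1 to compound 4, 1.1-fold (0.05 log units) apart, within the scatter of two such steps

Methoxy is the only group shown on this carbon. From the compounds shown here alone, whether an amine, a carboxylic acid or a longer chain there would move the number beyond the scatter stays open.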